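This account rests on a few compounds, and the source may have more. Where it says the series, first, only, none or still open, it means among the compounds named here.

This piece follows a single change made to compound 1 `CCCCCCNc1cncc(C(=O)NCc2ccccc2)n1` and asks what it should do in an ADME assay on MDCK cells (Canis lupus familiaris) for cytotoxicity, read by microscopy, with a stated time of 6 days; on this read-out higher numbers stand for lower toxicity in this test and lower numbers for higher toxicity in this test. Of the compounds shown here, three have numbers so far. Compound 1 gives 20000 nM. Compound 3 `CCCCCCCNc1nccnc1C(=O)NCc1ccccc1` gives 100000 nM. Compound 2 `CCCCNc1nccnc1C(=O)NCc1ccccc1` reaches only a limit of the test, > 100000 nM, so for it no exact number is known. Of the two real numbers, compound 1 is the lowest, and the gap from it up to compound 3 lies beyond the usual scatter of repeated measurements.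

Compound 4 `CCCCCCCCNc1cncc(C(=O)NCc2ccccc2)n1` differs from compound 1 in one spot: ethyl in place of hydrogen on a saturated chain carbon, six bonds along the chain from a nitrogen on an aromatic ring. The hydrogen leaves a saturated chain carbon and an ethyl takes its place, six bonds along the chain from a nitrogen on an aromatic ring.

For the measured compounds named here, one measured step bears on this: a number no higher from compound 2 to compound 3 (the limit leaves the size open). Going by these compounds, because compound 2 sits at a limit (the limit of > 100000 nM in this assay, at which 1 of the 3 values shown sits), the size of that step stays open; it only shows that growing the chain did not push the number up. Lengthening the chain on compound 1 is therefore expected to leave the number close to where it is, or move it slightly downward, a step of a 1.3-fold lower number from compound 1 to compound 4 (0.12 log units; within the scatter). Compound 4 is expected to give about 15000 nM, within 4000 nM to 60000 nM.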

Compound 4, minimum cytotoxic concentration: 4000 nM
Compound 4: middle estimate off by 3.8-fold (0.57 log units), on the high side; low and high end bracket the measured number.
By their numbers in this assay, from the lowest: compound 4; then compound 1; then compound 3.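

In this assay, ethyl in place of hydrogen, six bonds along the chain from a nitrogen on an aromatic ring, gives a step whose size can be read (a 5.0-fold lower number from compound 1 to compound 4 (0.70 log units; beyond the scatter)), and it points toward higher toxicity in this test. For the compounds shown here, the earlier chain step showed only that the number did not rise, and its size cannot be read, due to the value of compound 2 being a limit: the limit of > 100000 nM in this assay, at which 1 of the 4 values shown sits. Going by these compounds alone, this single pair therefore gives the first sized evidence that a longer chain on the core of compound 1 can lower the number, though it does not show why.

Going by these compounds, it remains open whether a still longer chain on this core would lower the number further or whether the trend would level off, and what an amine or a carboxylic acid at the end of the chain would do. On these data alone, it is also open whether the same ethyl change would have a similar effect on the different core shared by compound 2 and compound 3.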